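The compounds below may be only part of what the source reports. "The series", "measured", "known", "first", "only" and "open" are said of these compounds alone.

Among the compounds with values here, in a functional assay (trachea) with Cavia porcellus as the target (on this read-out lower numbers stand for stronger inhibition and higher numbers for weaker inhibition), compound 1 `CCCCCCCCn1nc(-c2cccnc2)c2ccccc2c1=O` gives 21900 nM, the highest of the three numbers so far. Compound 2 `CC(C)=CCn1nc(-c2cccnc2)c2ccccc2c1=O` gives 1380 nM, and compound 3 `O=c1c2ccccc2c(-c2cccnc2)nn1CC1CCCCC1` gives 209 nM. Compound 4 `O=c1c2ccccc2c(-c2cccnc2)nn1CCCCSc1ncccn1` is still unmeasured. Its difference from compound 1 is (pyrimidin-2-yl)sulfanyl in place of butyl on a saturated chain carbon, four bonds along the chain from an aromatic nitrogen.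

Two measured steps also replace the heptyl group of compound 1: a 16-fold lower number from compound 1 to compound 2 (1.20 log units; beyond the scatter) and a 100-fold lower number from compound 1 to compound 3 (2.02 log units; beyond the scatter). Both are large and go to lower numbers. Neither entering group holds a hetero atom, so they are only a loose guide to this change. A sizeable step to a lower number is nevertheless expected in this assay, with wide uncertainty. The estimated step is a 15-fold lower number from compound 1 to compound 4 (1.16 log units; beyond the scatter). For compound 4 the expected value is 1500 nM, with an estimated range of 200 nM to 10000 nM.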

Compound 4, half-maximal inhibitory concentration: 6170 nM
The estimate for compound 4 lay 4.1-fold (0.61 log units) below the measured number; the measured number falls inside the stated range.
By their numbers in this assay, from the lowest: compound 3; then compound 2; then compound 4; then compound 1.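

In this assay, (pyrimidin-2-yl)sulfanyl in place of butyl on a saturated chain carbon, four bonds along the chain from an aromatic nitrogen, gives a 3.5-fold lower number from compound 1 to compound 4 (0.55 log units; beyond the scatter), so an entering group with an aromatic ring and hetero atoms also moves the number down at this position. The direction matches the two earlier replacements of the heptyl group, yet compound 4 at 6170 nM stays above compound 2 at 1380 nM and compound 3 at 209 nM. No measurement at hand accounts for the size of this step.

Still open, from the compounds shown here alone, is whether the sulfur or the pyrimidin-2-yl ring sets this number, which phenylsulfanyl or (pyrimidin-2-yl)oxy on the same chain would separate. Also open, going by these compounds, is how a shorter or longer chain carrying the (pyrimidin-2-yl)sulfanyl group would read.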